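A few compounds are considered here, and "the series" means these few. Any claim that something is new, unique, unknown or untested is made for them only; others in the source may bear on it.

Of the compounds shown here, three that share one core have been tested in a functional assay on H9c2 cells (Mus musculus) for cytotoxicity against H9c2 (Rattus norvegicus), read by MTT assay, with a stated time of 24 h; on this read-out higher numbers stand for an effect only at larger amounts of compound and lower numbers for an effect already at smaller amounts. Compound 1 `O=c1c(Cc2ccc(C(F)(F)F)cc2)coc2cc(O)cc(O)c12` gives 12700 nM. Compound 3 `COc1cc(OC)c2c(=O)c(Cc3cccs3)coc2c1` gives 74300 nM in this assay. For compound 2 `COc1ccc(Cc2coc3cccc(O)c3c2=O)cc1` this assay reports only > 100000 nM, which is a limit of the assay rather than a measured number. Compound 2 therefore stands at the limit of > 100000 nM in this assay, at which 1 of the 3 values shown sits, the upper edge of what this assay can report, and its true value is not known more closely than that.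

Compound 4 `COc1ccc(Cc2coc3cc(OCC=C(C)C)cc(O)c3c2=O)cc1` has not yet been measured. Compared with compound 2 it carries (3-methylbut-2-en-1-yl)oxy in place of hydrogen on an aromatic carbon. Going by the values given here, no two of the measured compounds differ from each other in a single place, so no measured step of this kind is available, and the size of the change can only be guessed from the structures and from the spread of the three values shown. The step from compound 2 to compound 4 in this assay is expected to be an at least 1.4-fold lower number from compound 2 to compound 4 (0.15 log units; that floor lies within the scatter), in the direction of an effect at smaller amounts of compound, though with a real chance that the assay again reports only a limit. Compound 4 is estimated at 70000 nM, with a range from 20000 nM to 200000 nM.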

Compound 4, half-maximal effective concentration: > 100000 nM
Compound 4 ended at the assay's limit (the forecaster's own chance of this, stated with the estimate: 45%); middle value at least 1.4-fold (0.15 log units) from the limit.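

Compound 4, like compound 2, ends at a limit of this assay rather than at a measured number, so no step between these two compounds can be read: the limit of > 100000 nM in this assay, at which 2 of the 4 values shown sit.

The compounds shown leave open whether (3-methylbut-2-en-1-yl)oxy in place of hydrogen on an aromatic carbon changes the amount of compound needed for an effect at all.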